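This account rests on a few compounds, and the source may have more. Where it says the series, first, only, none or still open, it means among the compounds named here.

Compound 1 `O=C(NCc1ccccc1Br)N1C(=O)c2ccccc2S1(=O)=O`: 0.253 h
Compound 2 `O=C(NCc1ccccc1F)N1C(=O)c2ccccc2S1(=O)=O`: 0.598 h
Compound 3 `O=C(NCc1ccccc1Cl)N1C(=O)c2ccccc2S1(=O)=O`: 0.42 h

In a physicochemical assay for pharmacokinetics (a higher number here means that the compound lasts longer, a lower number that the compound disappears faster), compound 3 gives 0.42 h, which lies within the scatter of both other compounds: a 1.7-fold higher number from compound 1 to compound 3 (0.22 log units; within the scatter), and a 1.4-fold lower number from compound 2 to compound 3 (0.15 log units; within the scatter). Compound 4 `O=C(NCc1cccs1)N1C(=O)c2ccccc2S1(=O)=O` carries thiophen-2-yl in place of 2-chlorophenyl on a saturated chain carbon bound to an amide-type nitrogen. The measured steps only exchange one halogen for another on an aromatic carbon, so they bear on this change only indirectly. The largest of them, a 2.4-fold higher number from compound 1 to compound 2 (0.37 log units; beyond the scatter), is modest. Within the data shown here, no measured step replaces the whole 2-chlorophenyl, and no shift beyond the scatter can be predicted in either direction. The expected change is therefore small: a 1.1-fold lower number from compound 3 to compound 4 (0.02 log units; within the scatter). Compound 4 is estimated at 0.4 h, with an expected range from 0.2 h to 0.8 h.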

Compound 4, half-life: 0.365 h
Compound 4: middle estimate off by 1.1-fold (0.04 log units), on the high side; the measured number falls inside the stated range.
By their numbers in this assay, from the lowest: compounds 1, 4, 3 and 2 (each within the scatter of the next, the first and the last beyond it).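

Putting thiophen-2-yl on the saturated chain carbon bound to an amide-type nitrogen keeps this assay within the scatter of all three halogenated phenyl compounds (a 1.2-fold lower number from compound 3 to compound 4 (0.06 log units; within the scatter); a 1.6-fold lower number from compound 2 to compound 4 (0.21 log units; within the scatter); a 1.4-fold higher number from compound 1 to compound 4 (0.16 log units; within the scatter)). The position thus takes a five-membered aromatic ring with a sulfur atom in place of a whole six-membered halogenated ring without a shift beyond the scatter. Nothing available explains these numbers. From the compounds shown here alone, whether an amine, a carboxylic acid or a longer chain at this place would move the half-life beyond the scatter stays open.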